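A few compounds are considered here, and "the series" means these few. Any claim that something is new, unique, unknown or untested is made for them only; others in the source may bear on it.

Of the compounds shown here, three that share a core have been measured in an assay on LtK cells with ATP-sensitive inward rectifier potassium channel 11 (Homo sapiens) as the target; a higher number here means that more compound is needed for the effect, a lower number that less compound is needed. Compound 1 `CCC(=O)Nc1c(C(O)(C(F)(F)F)C(F)(F)F)ccc2ccccc12`, which carries an ethyl group on the carbonyl carbon, gives 15 nM. Compound 2 `O=C(Nc1c(C(O)(C(F)(F)F)C(F)(F)F)ccc2ccccc12)c1cccc(Br)c1`, with a 3-bromophenyl group in that place, gives 80 nM, and compound 3 `COc1ccc(C(=O)Nc2c(C(O)(C(F)(F)F)C(F)(F)F)ccc3ccccc23)cc1`, with a 4-methoxyphenyl group there, gives 417 nM. Compound 3 thus has the highest number of the three: the step of a 28-fold higher number from compound 1 to compound 3 (1.44 log units; beyond the scatter) is large, the step of a 5.2-fold higher number from compound 2 to compound 3 (0.72 log units; beyond the scatter) is modest, and the step of a 5.3-fold higher number from compound 1 to compound 2 (0.73 log units; beyond the scatter) shows that the 3-bromophenyl group already costs something against the ethyl group.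

Compound 4 `O=C(Nc1c(C(O)(C(F)(F)F)C(F)(F)F)ccc2ccccc12)c1cccc(Cl)c1Cl` has not yet been measured. It differs from compound 3 in one place: 2,3-dichlorophenyl in place of 4-methoxyphenyl on a carbonyl carbon. The measured step that bears most directly on this change is a 5.2-fold higher number from compound 2 to compound 3 (0.72 log units; beyond the scatter), which replaced a phenyl ring carrying a bromine with the 4-methoxyphenyl group; compound 4 goes the other way, back to a phenyl ring carrying halogens. The change from compound 3 to compound 4 is therefore expected to give a modest downward step, a 4.2-fold lower number from compound 3 to compound 4 (0.62 log units; beyond the scatter), in this assay. Compound 4 is estimated at 100 nM, with a likely range from 40 nM to 300 nM.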

Compound 4, half-maximal effective concentration: > 10000 nM
Compound 4 ended at the assay's limit; the forecaster's own chance of this, stated with the estimate: 2%; middle value at least 100-fold (2.00 log units) from the limit.
By their numbers in this assay, from the lowest: compound 1; then compound 2; then compound 3. At a limit, above all of these: compound 4.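

Compound 4 gives > 10000 nM in this assay as a limit of the assay and not as a number. Even read as minimum sizes, the steps to it are all large, with an at least 23-fold higher number from compound 3 to compound 4 (1.37 log units; beyond the scatter) and with an at least 120-fold higher number from compound 2 to compound 4 (2.09 log units; beyond the scatter) and with an at least 660-fold higher number from compound 1 to compound 4 (2.82 log units; beyond the scatter) on the same carbonyl carbon. The earlier compounds shown here showed only graded costs for a ring at this position, and compound 2 suggested that a phenyl ring carrying a halogen could still give a measurable number, whereas compound 4 shows that a halogen-carrying ring can push the number out of the assay's measurable range, so the presence of halogen alone does not tell how a ring will behave here.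

The compounds shown cannot separate the contribution of the second halogen from that of chlorine in place of bromine or from that of where the halogens sit on the ring. As far as these compounds go, how a phenyl ring with a single chlorine, an unsubstituted phenyl ring, a longer chain or an amine would read on this carbonyl carbon also remains open.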